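A few compounds are considered here, and "the series" means these few. Any claim that something is new, unique, unknown or untested is made for them only; others in the source may bear on it.

The measured compounds:
Compound 1, `CCCS(=O)(=O)c1cc(C2CC[C@@H](c3cc(OC)c(OC)c(OC)c3)O2)cc(OC)c1OCC[S+]([O-])c1ccc(O)cc1`, gives 25% in a functional assay on the whole organism for inhibition, with Rattus norvegicus as the target, at a dose of 1 mg/kg by the oral route; on this read-out lower numbers stand for less inhibition and higher numbers for more inhibition at the one dose given (going by the name of the read-out).
Compound 2, `CCCS(=O)(=O)c1cc(C2CC[C@@H](c3cc(OC)c(OC)c(OC)c3)O2)cc(OC)c1OCCS(=O)(=O)c1ccc(O)cc1`, gives 7% in this assay.
Compound 3, `CCCS(=O)(=O)c1cc(C2CC[C@@H](c3cc(OC)c(OC)c(OC)c3)O2)cc(OC)c1OCCSc1cccc(N)c1`, gives 7% in this assay.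

Compound 3 stands level with compound 2 at the digits reported, and the two together hold the lowest numbers of the three. Compound 1 is the furthest from compound 3: a number 18 percentage points lower from compound 1 to compound 3 (beyond the scatter). The two steps that set compound 1 apart, a number 18 percentage points lower from compound 1 to compound 2 (beyond the scatter) and a number 18 percentage points lower from compound 1 to compound 3 (beyond the scatter), each replace the whole group on the saturated chain carbon two bonds along the chain from the oxygen on the aromatic ring, while the step of no change at the digits printed from compound 2 to compound 3 (within the scatter) exchanges (4-hydroxyphenyl)sulfonyl for (3-aminophenyl)sulfanyl at that same place.

Compound 4, `CCCS(=O)(=O)c1cc(C2CC[C@@H](c3cc(OC)c(OC)c(OC)c3)O2)cc(OC)c1OCCSc1ccc(N)cc1`, has not yet been measured in this assay. It differs from compound 3 in one place: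
4-aminophenyl in place of 3-aminophenyl on a sulfur
Among the compounds with values here, none of the measured steps tests a change of this kind, a move of the amino group on the phenyl ring while the sulfur and the rest of the molecule stay the same. Within the data shown here, the only step that keeps the chain and alters the aryl group, from compound 2 to compound 3, lay within the scatter. With no closer guide, the step from compound 3 to compound 4 is expected to stay within the scatter, no change at the digits printed from compound 3 to compound 4 (within the scatter). Compound 4 is therefore estimated at 7%, with a range from 0% to 20%.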

Compound 4, a percentage reported as inhibition, in the whole organism at one dose (the size of the read-out at that dose, not a potency): 56%
Estimate against measurement, compound 4: 49 percentage points below; the measured number lies above the stated range.
By their numbers in this assay, from the lowest: compounds 2 and 3 (each within the scatter of the next); then compound 1; then compound 4.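

In this assay, exchanging 3-aminophenyl for 4-aminophenyl on the sulfur, with the chain and the rest of the molecule unchanged, gives a number 49 percentage points higher from compound 3 to compound 4 (beyond the scatter), so where the amino group sits on the phenyl ring matters strongly here, although both groups carry the same atoms and the same counts of donors and acceptors. Exchanging the whole group on the saturated chain carbon for (4-aminophenyl)sulfanyl also gives large steps, a number 49 percentage points higher from compound 2 to compound 4 (beyond the scatter) and a number 31 percentage points higher from compound 1 to compound 4 (beyond the scatter). The earlier level reading of compound 2 and compound 3 therefore did not mean that this place is indifferent to its aryl group, a point those compounds alone could not show.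

On these data alone, whether the result depends on the amino group itself or on any group placed as in 4-aminophenyl stays open, and a 4-hydroxyphenyl or a 4-(dimethylamino)phenyl group on the same sulfur would be needed to separate the two. No measurement given here explains why this single change in the amino group's place has so large an effect.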